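Benzylic ester variation in an antiproliferative series: limits throughout

The compounds below may be only part of what the source reports. "The series", "measured", "known", "first", "only" and "open" are said of these compounds alone.

Measured compounds:
compound 1, `C/C=C1/[C@H](O[C@@H]2O[C@H](CO)[C@@H](O)[C@H](O)[C@H]2O)OC=C(C(=O)OC)[C@H]1CC(=O)OCc1ccco1`: > 15000 nM, a limit of the assay.
compound 2, `C/C=C1/[C@H](O[C@@H]2O[C@H](CO)[C@@H](O)[C@H](O)[C@H]2O)OC=C(C(=O)OC)[C@H]1CC(=O)OCCc1ccc2c(c1)OCCO2`: > 20000 nM, a limit of the assay.
compound 3, `C/C=C1/[C@H](O[C@@H]2O[C@H](CO)[C@@H](O)[C@H](O)[C@H]2O)OC=C(C(=O)OC)[C@H]1CC(=O)OCCc1ccc(OC)cc1`: > 20000 nM, a limit of the assay.

Every result so far in a functional assay on SK-BR-3 cells (Homo sapiens) for antiproliferative activity, read by MTT assay, with a stated time of 72 h (a higher number here means a weaker inhibitor, a lower number a stronger inhibitor), is a limit rather than a number. Compound 3 stands at the limit of > 20000 nM in this assay, at which 2 of the 3 values shown sit. Compound 2 sits at the same limit. Compound 1 sits at the limit of > 15000 nM in this assay, at which 1 of the 3 values shown sits. Because all three sit at limits, the measured steps a step that the two limits leave unreadable from compound 1 to compound 2, a step that the two limits leave unreadable from compound 1 to compound 3 and a step that the two limits leave unreadable from compound 2 to compound 3 cannot be read in size or direction, and no bound on potency change for this part of the molecule can be taken from them.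

Compound 4, `C/C=C1/[C@H](O[C@@H]2O[C@H](CO)[C@@H](O)[C@H](O)[C@H]2O)OC=C(C(=O)OC)[C@H]1CC(=O)OCCc1ccccc1`, differs from compound 3 by hydrogen in place of methoxy on an aromatic carbon. The three esters examined so far, spanning furan-2-yl, (2,3-dihydro-1,4-benzodioxin-6-yl)methyl and 4-methoxybenzyl, all remained at the limit, so the expectation for compound 4 is no readable step either: the estimated step that the limit leaves unreadable from compound 3 to compound 4 is taken as nominal. Compound 4 is expected at about 25000 nM, within 10000 nM to 60000 nM, most likely reported again as a limit.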

Compound 4, half-maximal inhibitory concentration: 11000 nM
Compound 4: middle estimate off by 2.3-fold (0.36 log units), on the high side, and the stated range covers the measured number.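

In this assay, within the data shown here, compound 4, the phenethyl ester, is the only compound of the four with a number rather than a limit, so this position can now be read from one side. Hydrogen in place of methoxy gives an at least 1.8-fold lower number from compound 3 to compound 4 (0.25 log units; that floor lies within the scatter), phenyl in place of 2,3-dihydro-1,4-benzodioxin-6-yl gives an at least 1.8-fold lower number from compound 2 to compound 4 (0.25 log units; that floor lies within the scatter), and benzyl in place of furan-2-yl gives an at least 1.3-fold lower number from compound 1 to compound 4 (0.13 log units; that floor lies within the scatter), all three being floors only. Compound 2 and compound 3 remain limits: the limit of > 20000 nM in this assay, at which 2 of the 4 values shown sit.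

Going by these compounds, the true size of these steps stays open. Also open, on these data alone, is whether another group on this aromatic carbon, such as fluoro, an amine or a carboxylic acid, or a longer chain in place of phenethyl, would move the number further.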